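Cyanomethyl for benzyl on the tetrazole-like core of compound 3

The compounds below may be only part of what the source reports. "The series", "measured", "known", "first", "only" and "open" are said of these compounds alone.

Measured compounds:
Compound 1 `CC(C)(N)C(=O)N[C@H](COCc1ccccc1)c1nnnn1Cc1ccc(NS(C)(=O)=O)cc1` gives 259 nM in a functional assay on H4 cells for agonist activity at growth hormone secretagogue receptor type 1 (Homo sapiens), read by FLIPR; a lower number here means that less compound is needed, a higher number that more compound is needed for the effect.
Compound 2 `CC(C)(N)C(=O)N[C@H](COCc1ccccc1)c1nnnn1CCCCC#N` gives 35 nM in this assay.
Compound 3 `CC(C)(N)C(=O)N[C@H](COCc1ccccc1)c1nnn(Cc2ccccc2)n1` gives 1120 nM in this assay.

Among these three, compound 3 stands with the highest number; compound 1 is the nearest and compound 2 is the furthest, both with steps beyond the scatter. Compound 4 `CC(C)(N)C(=O)N[C@H](COCc1ccccc1)c1nnn(CC#N)n1` differs from compound 3 by cyano in place of phenyl on a saturated chain carbon bound to an aromatic nitrogen. Going by the values given here, one measured step bears on this: a 7.4-fold lower number from compound 1 to compound 2 (0.87 log units; beyond the scatter), where an aromatic substituent on the same kind of carbon gave way to a short chain ending in a nitrile and the number fell by a modest amount. Among the compounds with values here, the change from compound 3 to compound 4 likewise trades an aromatic ring for a nitrile-bearing group, though the chain is shorter and the starting core is that of compound 3, for which no parallel step exists. A lower number of modest size is therefore expected, a 3.2-fold lower number from compound 3 to compound 4 (0.51 log units; beyond the scatter). Compound 4 is estimated at 350 nM, within 120 nM to 1200 nM.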

Compound 4, half-maximal effective concentration: 1520 nM
Beside the measured number, compound 4's estimate is 4.3-fold (0.64 log units) below it; measured number outside the range, above it.
By their numbers in this assay, from the lowest: compound 2; then compound 1; then compounds 3 and 4 (each within the scatter of the next).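

On the core of compound 3, benzyl and cyanomethyl are not told apart in this assay: the change gives a 1.4-fold higher number from compound 3 to compound 4 (0.13 log units; within the scatter), so replacing phenyl with cyano on a saturated chain carbon bound to an aromatic nitrogen leaves no measurable change, despite the smaller group. A nitrile at this place therefore does not by itself lower the number on this core, whereas the change on the core of compound 1 to the longer 3-cyanopropyl gave a 7.4-fold lower number from compound 1 to compound 2 (0.87 log units; beyond the scatter). No measurement shown here accounts for this difference between the two steps.

Going by these compounds, it remains open whether 3-cyanopropyl on the core of compound 3 would lower the number as it did on the core of compound 1, which would separate the effect of chain length from that of the core. On these data alone, how an amine or a carboxylic acid in place of the cyano would read on either core is also open.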